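Swapping the aryl group on a sugar-bearing coumarin triazole

The compounds below may be only part of what the source reports. "The series", "measured", "known", "first", "only" and "open" are said of these compounds alone.

Of the compounds shown here, three have been measured in a functional assay on MCF7 cells (Homo sapiens) for antiproliferative activity; a higher number here means a weaker inhibitor, a lower number a stronger inhibitor. Compound 1 `Cc1c(O)ccc2cc(-n3cc(-c4ccc(F)cc4F)nn3)c(=O)oc12` gives 33500 nM. Compound 3 `COc1ccc(-c2cn(-c3cc4ccc(O)c(C)c4oc3=O)nn2)cc1` differs from compound 1 in one place: 4-methoxyphenyl in place of 2,4-difluorophenyl on an aromatic carbon. In this assay compound 3 reaches only a limit of the assay, > 100000 nM. That change therefore made the step of an at least 2.9-fold higher number from compound 1 to compound 3 (0.47 log units; beyond the scatter).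

Compound 2 `CO[C@@H]1[C@@H](O)[C@@H](O)[C@H](Oc2ccc3c(c2C)OC(=O)C(n2cc(-c4ccc(F)cc4F)nn2)C3)OC1(C)C` carries a different core, with a sugar attached; the difference between the two cores is not broken down here. In this assay compound 2 also gives only a limit, > 100000 nM. Across the three measured compounds, two sit at the same point: the limit of > 100000 nM in this assay, at which 2 of the 3 values shown sit.

Compound 4 `COc1ccc(-c2cn(C3Cc4ccc(O[C@@H]5OC(C)(C)[C@H](OC)[C@@H](O)[C@H]5O)c(C)c4OC3=O)nn2)cc1` has not yet been measured. It differs from compound 2 by the same change that separates compound 1 from compound 3: 4-methoxyphenyl in place of 2,4-difluorophenyl on an aromatic carbon.

What can be expected rests on two things: the measured step of that change, an at least 2.9-fold higher number from compound 1 to compound 3 (0.47 log units; beyond the scatter), which weakened inhibition, and the fact that the starting point already sits at the limit. The step is accordingly expected to be a step that the limit leaves unreadable from compound 2 to compound 4. Compound 4 is expected to give about 250000 nM, which in practice most likely means that the assay will again report only a limit and no number.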

Compound 4, half-maximal inhibitory concentration: > 100000 nM
Compound 4 gave a limit, no number; the forecaster's own chance of this, stated with the estimate: 90%; the middle value lies beyond the limit too.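

In this assay compound 4 gives > 100000 nM, which is a limit of the assay and not a number. Compound 2 also stands at a limit, so the swap between compound 2 and compound 4 cannot be read as a step. The compounds shown leave open whether 4-methoxyphenyl weakens inhibition on the sugar-bearing core as it did on the core of compound 1. Most values now sit at one point: the limit of > 100000 nM in this assay, at which 3 of the 4 values shown sit.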